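Replacing the 2,5-dihydroxyphenyl group of compound 2

A few compounds are considered here, and "the series" means these few. Any claim that something is new, unique, unknown or untested is made for them only; others in the source may bear on it.

Of the compounds shown here, three have been measured in a functional assay on cells (Cancer cell lines, Homo sapiens) for cytotoxicity, read by sulforhodamine B assay, with a stated time of 48 h; a lower number here means a stronger inhibitor of growth, a higher number a weaker inhibitor of growth. Compound 1 `Oc1ccc(O)c(-c2cc(-c3ccccc3)nn2-c2ccccc2)c1` gives 18600 nM. Compound 2 `Oc1ccc(O)c(-c2cc(-c3ccc(Cl)cc3)nn2-c2ccccc2)c1` gives 17900 nM, and compound 3 `NS(=O)(=O)c1ccc(-n2nc(-c3ccc(Cl)cc3)cc2-c2cc(O)ccc2O)cc1` gives 17800 nM. Compound 2 sits within the scatter of both neighbours: the step of a 1.0-fold lower number from compound 1 to compound 2 (0.02 log units; within the scatter) and the step of a 1.0-fold lower number from compound 2 to compound 3 (0.00 log units; within the scatter) are both flat, so the three numbers cannot be told apart.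

Compound 4 `O=C1C=CC(=O)C(c2cc(-c3ccc(Cl)cc3)nn2-c2ccccc2)=C1` has not been measured. It differs from compound 2 by a group of 8 heavy atoms (6 carbon, 2 oxygen; one six-membered non-aromatic ring of carbon only) in place of a group of 8 heavy atoms (6 carbon, 2 oxygen; one six-membered aromatic ring of carbon only), on an aromatic carbon. Neither measured step touches this part of the molecule: the step from compound 1 to compound 2 adds a chloro group on the 4-chlorophenyl ring, and the step from compound 2 to compound 3 adds a sulfamoyl group on the phenyl ring on the ring nitrogen, both leaving this assay unchanged. Within the data shown here, the change to compound 4 is of a different kind, and no measured pair gives a size for it.

With nothing bearing on the change, the expectation for compound 4 rests on compound 2 and is given a wide range. Compound 4 is estimated at 12000 nM, between 3000 nM and 40000 nM, which is expected to be a step of a 1.5-fold lower number from compound 2 to compound 4 (0.17 log units; within the scatter).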

Compound 4, concentration for 50% growth inhibition: 65400 nM
For compound 4 the middle estimate is 5.5-fold (0.74 log units) below the measured one, and the stated range ends below it.
By their numbers in this assay, from the lowest: compounds 3, 2 and 1 (each within the scatter of the next); then compound 4.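

In this assay, among these compounds, this is the first change with a step beyond the scatter: a 3.7-fold higher number from compound 2 to compound 4 (0.56 log units; beyond the scatter), on swapping the 2,5-dihydroxyphenyl group, with its 2 hydrogen-bond donors, for a group with one six-membered non-aromatic ring of carbon only and 0 hydrogen-bond donors. The chloro and sulfamoyl steps elsewhere on the molecule left the number flat, so the aromatic carbon next to the ring nitrogen is the only place shown so far where a change moves the read-out, and the move here is towards weaker growth inhibition. Nothing measured alongside these numbers speaks to what lies behind the step.

The compounds shown do not separate the loss of the aromatic ring from the loss of the hydrogen-bond donors, a question that a 2,5-dimethoxyphenyl group or an aminophenyl group at this place would bear on. Also open, from the compounds shown here alone, is whether the same replacement gives a step of similar size on the core of compound 1 or compound 3.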